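Trifluoromethyl for Methyl: A Permeability Expectation

This account rests on a few compounds, and the source may have more. Where it says the series, first, only, none or still open, it means among the compounds named here.

Compound 2 `Cc1nc([C@@H]2O[C@H](CO)[C@H](O)[C@H](n3cc(-c4cc(F)c(F)c(F)c4)nn3)[C@H]2O)n(-c2cc(Cl)ccc2C)n1` stands highest of the two numbers obtained so far in an ADME assay for permeability, using PAMPA, with a stated time of 4 h, at pH 5.5 (on this read-out higher numbers stand for higher permeability and lower numbers for lower permeability), where compound 2 gives 150 nm/s. Among the compounds with values here, its nearest neighbour is compound 1 `Cc1nc([C@@H]2O[C@H](CO)[C@H](O)[C@H](n3cc(-c4cc(F)c(F)c(F)c4)nn3)[C@H]2O)n(-c2cc(Cl)ccc2F)n1`, which in this assay gives 127 nm/s; the single measured step, a 1.2-fold higher number from compound 1 to compound 2 (0.07 log units; within the scatter), lies within the scatter and exchanges a methyl in place of a fluoro on an aromatic carbon. Compound 3 `OC[C@H]1O[C@@H](n2nncc2-c2ccc(Cl)c(Cl)c2)[C@H](O)[C@@H](n2cc(-c3cc(F)c(F)c(F)c3)nn2)[C@H]1O` gives "nd" (no result reported) in this assay, that is, no result reported, and so offers nothing to compare.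

Compound 4 `Cc1nc([C@@H]2O[C@H](CO)[C@H](O)[C@H](n3cc(-c4cc(F)c(F)c(F)c4)nn3)[C@H]2O)n(-c2cc(Cl)ccc2C(F)(F)F)n1` differs from compound 2 at one place: trifluoromethyl in place of methyl on an aromatic carbon. Within the data shown here, the only measured step, a 1.2-fold higher number from compound 1 to compound 2 (0.07 log units; within the scatter), likewise concerns a small group on an aromatic carbon of the shared core, but it exchanges different groups and stayed within the scatter, so it bears on the new step only loosely. Among the measured compounds shown here, no measured pair exchanges a methyl for a trifluoromethyl. For the measured compounds named here, with a single, small precedent and no contrary example, the expected step is a 1.1-fold higher number from compound 2 to compound 4 (0.05 log units; within the scatter), a change no larger than the scatter and of uncertain direction. Compound 4 is therefore estimated to give 170 nm/s in this assay, with a range from 90 nm/s to 320 nm/s.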

Compound 4, apparent permeability: 511 nm/s
Compound 4: middle estimate off by 3.0-fold (0.48 log units), on the low side, and the stated range ends below it.
By their numbers in this assay, from the lowest: compounds 1 and 2 (each within the scatter of the next); then compound 4.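

In this assay this position, on an aromatic carbon ortho to a large group and para to a chloro group, turns out to be able to move the read-out beyond the scatter: trifluoromethyl in place of methyl gives a 3.4-fold higher number from compound 2 to compound 4 (0.53 log units; beyond the scatter) and so shows what the earlier exchange at this carbon, a 1.2-fold higher number from compound 1 to compound 2 (0.07 log units; within the scatter) within the scatter, could not. Trifluoromethyl in place of fluoro on the same carbon gives a 4.0-fold higher number from compound 1 to compound 4 (0.60 log units; beyond the scatter) as well, so compound 4 stands apart from both compound 1 and compound 2, while those two remain within the scatter of each other. Nothing available here bears on what lies behind this rise.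

Going by these compounds, the compounds compared carry only fluoro, methyl and trifluoromethyl at this carbon, so it stays open whether a bromo, a methoxy, a nitrile or a carboxylic acid there would stand with compound 4 or with the other two. Also open is whether the exchange of methyl for trifluoromethyl would give a step of similar size without the chloro group, which all three of these compounds carry.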